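Swapping a Cyclobutylmethyl Ether for a Nitrogen-Containing Ring

The source may report more compounds than this note shows. Statements on the series, on what has been measured and on what is new or still open speak of the compounds shown alone.

Compound 1 `O=C(O)CCn1c(=O)oc2cc(OCC3CCC3)c(Cl)cc21` was examined in a physicochemical assay for lipophilicity, read by HPLC, at pH 7.4 (a lower number here means a more polar compound, a higher number a more lipophilic compound), where compound 1 gives 2.9. Among the three measured compounds it has the second highest number. Compound 2 `Cc1ccc([C@@H](C)Oc2cc3onc(CCC(=O)O)c3cc2Cl)nn1` gives 2.97 in this assay, a value within the scatter of compound 1. Compound 3 `C[C@@H](Oc1cc2c(cc1Cl)N(CCC(=O)O)C(=O)CO2)c1ccccn1` gives 1.56, well beyond the scatter below compound 1. Compound 4 `C[C@@H](Oc1cc2oc(=O)n(CCC(=O)O)c2cc1Cl)c1ncccn1` has not yet been measured. It differs from compound 1 in one place: a group of 8 heavy atoms (6 carbon, 2 nitrogen; one six-membered aromatic ring with 2 hetero atoms) in place of a group of 5 heavy atoms (5 carbon; one four-membered non-aromatic ring of carbon only), on an oxygen on an aromatic ring. Within the data shown here, no measured pair shows this exact change, so the size of the step is uncertain. Because compound 3 gives 1.56 with a related nitrogen-containing side chain, a decrease beyond the scatter is expected, estimated as a number 0.80 log units lower from compound 1 to compound 4 (beyond the scatter). Compound 4 is therefore expected to give 2.1, within a range from 1.5 to 2.7.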

Compound 4, distribution coefficient: 0.83
Estimate against measurement, compound 4: 1.27 log units above; measured number below the stated range.
By their numbers in this assay, from the lowest: compound 4; then compound 3; then compounds 1 and 2 (each within the scatter of the next).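

On an oxygen on an aromatic ring, replacing cyclobutylmethyl with the group that holds a six-membered aromatic ring with 2 hetero atoms gives a number 2.07 log units lower from compound 1 to compound 4 (beyond the scatter) in this assay on the shared core. Among these compounds, this is the first step read at this position, and it shows that this single change is large in this read-out. No measurement on hand accounts for its size.

The compounds shown leave open how much of the step belongs to the ring nitrogens and how much to the rest of the entering group. A phenyl ring on the same oxygen would separate the two.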